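Biaryl acylsulfonamide series: replacing the dimethylcarbamoyl arm

A few compounds are considered here, and "the series" means these few. Any claim that something is new, unique, unknown or untested is made for them only; others in the source may bear on it.

Two compounds of the series carry numbers. For the measured compounds named here, compound 1 `COc1cc(C(=O)N(C)C)ccc1-c1ccc(C(=O)NS(=O)(=O)c2ccc(NCCSc3ccccc3)c([N+](=O)[O-])c2)cc1` gives 1980 nM in an assay on isolated protein for binding affinity to Apoptosis regulator Bcl-2 (Homo sapiens), read by fluorescence polarization (on this read-out higher numbers stand for weaker inhibition and lower numbers for stronger inhibition), the highest of the two values; compound 2 `CN(C)CCC[C@H](CSc1ccccc1)Nc1ccc(S(=O)(=O)NC(=O)c2ccc(N3CCC(C)(C)CC3)cc2)cc1[N+](=O)[O-]` gives 92.1 nM in this assay, a markedly lower number, and the two differ in several places at once, so no single step is read from them. Compound 3 `COc1cc(CCCO)ccc1-c1ccc(C(=O)NS(=O)(=O)c2ccc(NCCSc3ccccc3)c([N+](=O)[O-])c2)cc1` remains to be measured. It differs from compound 1 in one place: 3-hydroxypropyl in place of dimethylcarbamoyl on an aromatic carbon. Going by the values given here, no pair of measured compounds carries this change, so nothing sets its size. The swap exchanges one neutral arm of similar length for another, and the expected step from compound 1 to compound 3 is a 1.3-fold higher number from compound 1 to compound 3 (0.10 log units; within the scatter), small and not clearly beyond the scatter. For compound 3 the estimate in this assay is 2500 nM, with a range from 700 nM to 9000 nM.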

Compound 3, inhibition constant: 721 nM
Compound 3: the middle estimate sits 3.5-fold (0.54 log units) above what was measured; the range from low to high includes it.
By their numbers in this assay, from the lowest: compound 2; then compound 3; then compound 1.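

In this assay, the aromatic carbon meta to a methoxy group and para to a large group responds to the arm it carries: 3-hydroxypropyl in place of dimethylcarbamoyl gives a 2.7-fold lower number from compound 1 to compound 3 (0.44 log units; beyond the scatter) and this lies beyond the scatter. The number therefore does not depend on keeping the dimethylcarbamoyl group, and the lower value comes with a hydrogen-bond donor entering, one heavy atom fewer and the nitrogen gone, differences that this single pair cannot separate. Nothing measured here accounts for the step.

Open, on these data alone, is whether the terminal hydroxyl matters or the chain alone suffices, which a plain propyl chain would test. A longer chain ending in hydroxyl, a terminal amine or a carboxylic acid would show how far this position extends the trend.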